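Adding a Methoxybenzyl Arm to a Phenyl-Bearing Amidine

This account rests on a few compounds, and the source may have more. Where it says the series, first, only, none or still open, it means among the compounds named here.

Compound 2 `CN1CCN(c2ccc(NC(=N)c3cc4c(-c5ccccc5)nn(C)c4cn3)cc2)CC1` and compound 1 `COc1ccc(Cn2ncc3cc(C(=N)Nc4ccc(N5CCN(C)CC5)cc4)ncc32)cc1` share a core and the same amidine-linked aryl piperazine tail; they differ in what sits on the ring nitrogen and in whether a phenyl is present. In a functional assay on MDA-MB-231 cells (Homo sapiens) for cytotoxicity, read by MTT assay, with a stated time of 72 h (a lower number here means a stronger inhibitor, a higher number a weaker inhibitor), compound 2 gives 4900 nM, and compound 1 gives 5700 nM. Compound 2 holds the lower of the two numbers, yet the gap to compound 1 lies within the scatter, so the two compounds cannot be told apart on this evidence.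

Compound 3 `COc1ccc(Cn2nc(-c3ccccc3)c3cc(C(=N)Nc4ccc(N5CCN(C)CC5)cc4)ncc32)cc1` keeps the phenyl of compound 2 and adds the change (4-methoxyphenyl in place of hydrogen on a saturated chain carbon bound to an aromatic nitrogen). Compound 1 already carries this 4-methoxybenzyl group, but without the phenyl, and its number sits close to that of compound 2. No single-step comparison has been measured for this change, so the expectation rests only on the two values shown, which suggest the group neither helps nor hurts much here. The step from compound 2 to compound 3 is therefore expected to be a 1.1-fold lower number from compound 2 to compound 3 (0.04 log units; within the scatter), nothing beyond the scatter. Compound 3 is estimated at 4500 nM, with a range from 1500 nM to 13000 nM.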

Compound 3, half-maximal inhibitory concentration: 1760 nM
Beside the measured number, compound 3's estimate is 2.6-fold (0.41 log units) above it; the measured number falls inside the stated range.
By their numbers in this assay, from the lowest: compound 3; then compounds 2 and 1 (each within the scatter of the next).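

In this assay, among these compounds, this result gives the first direct readings of the two differences, since compound 1 and compound 2 differ from each other in two places and could not separate them. Putting 4-methoxyphenyl in place of hydrogen on a saturated chain carbon bound to an aromatic nitrogen gives a 2.8-fold lower number from compound 2 to compound 3 (0.44 log units; beyond the scatter) and turns the methyl of compound 2 into a 4-methoxybenzyl group, a step that clears the scatter. Putting phenyl in place of hydrogen on an aromatic carbon gives a 3.2-fold lower number from compound 1 to compound 3 (0.51 log units; beyond the scatter) and also clears it, so among these three compounds each group lowers the number when the other is already present, though both steps are modest.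

On these data alone, whether the methoxy on the arm matters remains open, as does the effect of a plain benzyl, a 4-hydroxybenzyl or a longer chain ending in an amine at this position, and the effect of either group without the other cannot be read from these compounds. No measurement offered here accounts for why the number falls with these changes.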